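The source may report more compounds than this note shows. Statements on the series, on what has been measured and on what is new or still open speak of the compounds shown alone.

Measured in a functional assay on HeLa cells (Homo sapiens) for cytotoxicity, read by MTT assay, with a stated time of 24 h; a lower number here means a stronger inhibitor, a higher number a weaker inhibitor:
- compound 1 `CCCCCCCC/C=C\CCCCCCCC(=O)Nc1nnc(S[C@@H]2O[C@H](COC(C)=O)[C@H](OC(C)=O)[C@H](OC(C)=O)[C@H]2OC(C)=O)s1`: 54400 nM
- compound 2 `CCCCCCCCCC(=O)Nc1nnc(S[C@@H]2O[C@H](CO)[C@H](O)[C@H](O)[C@H]2O)s1`: 25900 nM
- compound 3 `CCCCCCCC/C=C\CCCCCCCCCCCC(=O)Nc1nnc(S[C@@H]2O[C@H](CO)[C@H](O)[C@H](O)[C@H]2O)s1`: 13500 nM

Compound 1 has the highest number of the three, and its gaps to compound 2 and to compound 3 both lie beyond the scatter. The next compound to be measured is compound 4 `CCCCCCCCCCCCCCCC(=O)Nc1nnc(S[C@@H]2O[C@H](COC(C)=O)[C@H](OC(C)=O)[C@H](OC(C)=O)[C@H]2OC(C)=O)s1`. It keeps the core of compound 1 and changes only the chain: octyl in place of dec-1-en-1-yl on a saturated chain carbon, seven bonds along the chain from a carbonyl carbon. In words, octyl replaces dec-1-en-1-yl on a saturated chain carbon, seven bonds along the chain from a carbonyl carbon.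

Going by the values given here, only one measured step concerns the chain, a 1.9-fold lower number from compound 2 to compound 3 (0.28 log units; within the scatter), and it stays within the scatter. Among the compounds with values here, it is only indirect evidence, since compound 2 and compound 3 lack the acetyl groups of compound 1, and no measured pair isolates the loss of the double bond. On that evidence, no shift beyond the scatter is expected in this assay. The estimated step is a 1.1-fold lower number from compound 1 to compound 4 (0.04 log units; within the scatter). Compound 4 is expected at 50000 nM, with an estimated range of 22000 nM to 110000 nM.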

Compound 4, half-maximal inhibitory concentration: 58300 nM
Beside the measured number, compound 4's estimate is 1.2-fold (0.07 log units) below it, within the range that was stated.
By their numbers in this assay, from the lowest: compounds 3 and 2 (each within the scatter of the next); then compounds 1 and 4 (each within the scatter of the next).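

In this assay the exchange of dec-1-en-1-yl for octyl on a saturated chain carbon, seven bonds along the chain from a carbonyl carbon, gives a 1.1-fold higher number from compound 1 to compound 4 (0.03 log units; within the scatter) and stays within the scatter. Going by these compounds alone, this is the first pair that keeps the acetyl groups of compound 1 and changes only the chain, so the step no longer has to be inferred from the deacetylated compounds. Loss of the double bond and the change in chain length arrive together here, and the pair cannot separate them, so the two could offset each other; nothing available explains the result.

Open, on these data alone, is whether a much shorter chain, or an amine or a carboxylic acid at the chain end, would shift the number on this acetylated core. Also open is the effect of the acetyl groups themselves: no pair shown differs in those groups alone.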